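A Halogen Swap on the Phenyl Ring and Liver Microsome Stability

The compounds below may be only part of what the source reports. "The series", "measured", "known", "first", "only" and "open" are said of these compounds alone.

Measured so far:
compound 1 `Nc1nc(NCCNc2ncc(-c3ncc[nH]3)c(-c3ccc(Cl)cc3)n2)ccc1[N+](=O)[O-]` — > 0.5 h
compound 2 `Nc1nc(NCCNc2ncc(-c3ncc[nH]3)c(-c3cc(F)c(F)cc3F)n2)ccc1[N+](=O)[O-]` — > 0.5 h

Compound 1 `Nc1nc(NCCNc2ncc(-c3ncc[nH]3)c(-c3ccc(Cl)cc3)n2)ccc1[N+](=O)[O-]` reaches only a limit in an ADME assay on microsomes from liver (Rattus norvegicus) for metabolic stability (on this read-out lower numbers stand for a shorter-lived compound and higher numbers for a longer-lived compound), reported as > 0.5 h. Compound 2 `Nc1nc(NCCNc2ncc(-c3ncc[nH]3)c(-c3cc(F)c(F)cc3F)n2)ccc1[N+](=O)[O-]` likewise reaches only a limit in this assay, reported as > 0.5 h. Going by the values given here, the one measured change, a step that the two limits leave unreadable from compound 1 to compound 2, therefore cannot be read, and all that is known is the limit of > 0.5 h in this assay, at which 2 of the 2 values shown sit.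

Compound 3 `Nc1nc(NCCNc2ncc(-c3ncc[nH]3)c(-c3cc(F)ccc3Cl)n2)ccc1[N+](=O)[O-]` differs from compound 1 by 2-chloro-5-fluorophenyl in place of 4-chlorophenyl on an aromatic carbon. Among the compounds with values here, no measured step resolves a number for this kind of change, and the two values shown are both limits. The expectation for compound 3 is thus that it, too, is likely to sit at the limit in this assay, with an estimated half-life of 1 h, between 0.4 h and 3 h. The expected step that the limit leaves unreadable from compound 1 to compound 3 is accordingly an estimate, not a reading from the data.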

Compound 3, half-life: > 0.5 h
Compound 3 was reported as a limit; the forecaster's own chance of this, stated with the estimate: 70%; the middle value is on the limit's open side.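

Compound 3 also gives only a limit, so neither its step from compound 1 nor its step from compound 2 can be read: the limit of > 0.5 h in this assay, at which 3 of the 3 values shown sit.

As far as these compounds go, the true half-lives of compound 1, compound 2 and compound 3 in this assay stay open, as does whether these phenyl changes alter them at all.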